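The compounds below may be only part of what the source reports. "The series", "measured", "known", "first", "only" and "open" are said of these compounds alone.

In a functional assay on MCF7 cells (Homo sapiens) for antiproliferative activity, read by MTT assay, with a stated time of 48 h (on this read-out lower numbers stand for stronger inhibition and higher numbers for weaker inhibition), three compounds built on a shared core have been measured so far. Compound 1 `O=[N+]([O-])c1cc(C(F)(F)F)cc([N+](=O)[O-])c1Oc1ccccc1/C=N\OCc1ccccc1F` gives 700 nM, compound 2 `O=[N+]([O-])c1cc(C(F)(F)F)cc([N+](=O)[O-])c1Oc1ccc(Cl)cc1/C=N\OCc1ccccc1F` gives 1110 nM, and compound 3 `O=[N+]([O-])c1cc(C(F)(F)F)cc([N+](=O)[O-])c1Oc1ccc(Cl)cc1/C=N\OCc1ccccc1Cl` gives 3950 nM. Compound 2 lies within the scatter of compound 1, whereas compound 3 has a clearly higher number than compound 2.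

Compound 4 `O=[N+]([O-])c1cc(C(F)(F)F)cc([N+](=O)[O-])c1Oc1ccc(Br)cc1/C=N\OCc1ccccc1F` has not yet been measured. Its structure departs from that of compound 2 in a single change: bromo in place of chloro on an aromatic carbon. In words, this is bromo in place of chloro on an aromatic carbon.

For the measured compounds named here, no measured step involves bromo, so the evidence is indirect. The closest step is the one that introduces the chloro group, a 1.6-fold higher number from compound 1 to compound 2 (0.20 log units; within the scatter), and it stays within the scatter. The other halogen exchange, chloro in place of fluoro on an aromatic carbon, gives a 3.6-fold higher number from compound 2 to compound 3 (0.55 log units; beyond the scatter). That modest step lies beyond the scatter, but it occurs at a different place in the molecule, so it carries less weight here.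

No step beyond the scatter is therefore expected in this assay, perhaps only a slight drift towards a higher number. The expected change is a 1.1-fold higher number from compound 2 to compound 4 (0.03 log units; within the scatter). For compound 4 the estimated value is 1200 nM, with an expected range from 550 nM to 2800 nM.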

Compound 4, half-maximal inhibitory concentration: 1120 nM
For compound 4 the middle estimate is 1.1-fold (0.03 log units) above the measured one, and the stated range covers the measured number.
By their numbers in this assay, from the lowest: compounds 1, 2 and 4 (each within the scatter of the next); then compound 3.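

In this assay, for the compounds shown here, the exchange of chloro for bromo at this position gives a 1.0-fold higher number from compound 2 to compound 4 (0.00 log units; within the scatter) and so leaves the number unchanged, which the earlier compounds could not show, as none of them carried bromo. Measured against hydrogen at the same aromatic carbon, bromo gives a 1.6-fold higher number from compound 1 to compound 4 (0.20 log units; within the scatter) and thus behaves like chloro, whose own step is a 1.6-fold higher number from compound 1 to compound 2 (0.20 log units; within the scatter), so at this place, meta to a large group and para to a large group, neither halogen moves the number beyond the scatter. Nothing measured here accounts for why these two halogens give such similar numbers.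

The compounds shown leave open whether a group of another kind at this position, such as an amine, a methoxy group or a carboxylic acid, would also stay within the scatter of hydrogen. They also leave open whether bromo would be tolerated as well at the site where the fluoro of compound 2 stands, since the exchange there to chloro gives a 3.6-fold higher number from compound 2 to compound 3 (0.55 log units; beyond the scatter) and lies beyond the scatter.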